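Ring size on the carbamate nitrogen: cyclopropyl to cyclobutyl

The source may report more compounds than this note shows. Statements on the series, on what has been measured and on what is new or still open speak of the compounds shown alone.

Measured so far:
compound 1 `COc1ccc(CC(=O)O)cc1-c1ccc(C(F)(F)F)cc1CNC(=O)OCc1ccccc1` — 45 nM
compound 2 `COc1ccc(CC(=O)O)cc1-c1ccc(C(F)(F)F)cc1CN(C(=O)OCc1ccccc1)C1CC1` — 4 nM

Within the data shown here, in an in vitro assay on 293T cells for displacement of a labelled ligand from prostaglandin D2 receptor 2 (Homo sapiens), read by scintillation counting (on this read-out higher numbers stand for weaker inhibition and lower numbers for stronger inhibition), compound 2 gives the lower of the two numbers, and the only measured step is the one from compound 1 to compound 2, an 11-fold lower number from compound 1 to compound 2 (1.05 log units; beyond the scatter). Compound 3 `COc1ccc(CC(=O)O)cc1-c1ccc(C(F)(F)F)cc1CN(C(=O)OCc1ccccc1)C1CCC1` takes this one step further: cyclobutyl in place of cyclopropyl on an amide-type nitrogen. Among the measured compounds shown here, no measured step bears directly on a change of ring size on this nitrogen; the single step shows that a small carbocycle on the amide-type nitrogen is well tolerated and favourable relative to hydrogen, but it gives no indication of how a four-membered ring compares with a three-membered one. The expectation for compound 3 is therefore no step beyond the scatter, no change at the digits printed from compound 2 to compound 3 (within the scatter). Compound 3 is estimated at 4 nM, with a range from 1.5 nM to 12 nM.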

Compound 3, half-maximal inhibitory concentration: 4 nM
Compound 3: middle estimate and measured number agree at the digits printed; the measured number falls inside the stated range.
By their numbers in this assay, from the lowest: compounds 2 and 3 (each within the scatter of the next); then compound 1.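

In this assay, cyclobutyl in place of cyclopropyl on the amide-type nitrogen gives no change at the digits printed from compound 2 to compound 3 (within the scatter), so the benefit of a carbocycle at this position is not confined to the three-membered ring. Replacing hydrogen with cyclobutyl gives an 11-fold lower number from compound 1 to compound 3 (1.05 log units; beyond the scatter), which matches at the printed digits the step seen with cyclopropyl, an 11-fold lower number from compound 1 to compound 2 (1.05 log units; beyond the scatter). No measurement presented here accounts for the two rings reading alike.

The compounds shown leave open whether this tolerance continues past the four-membered ring, as with a cyclopentyl ring, or holds for an open isopropyl chain or an oxetane ring on the same nitrogen. They also leave open whether a cyclobutyl group would read the same with a group other than benzyl on the carbamate oxygen.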